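The compounds below may be only part of what the source reports. "The series", "measured", "known", "first", "only" and "open" are said of these compounds alone.

Measured in an ADME assay on the whole organism (Mus musculus, strain CD1) for pharmacokinetics, read by LC-MS, with a stated time of 24 h, at a dose of 1 mg/kg by the intravenous route; a lower number here means that more of the compound stays in the plasma, a higher number that more of the compound sits outside the plasma:
- compound 1 `CCOc1cc2[nH]c(Cc3nn(CC(=O)O)c(=O)c4ccccc34)nc2cc1Cl`: 10 L/kg
- compound 2 `CC(C(=O)O)c1nn(Cc2cn3cc(OCC4CC4)c(C(F)(F)F)cc3n2)c2ccccc2c1=O`: 94 L/kg

Compound 1 holds the lower of the two numbers, and compound 2 lies beyond the scatter above it. Compound 3 `O=C(O)Cn1nc(Cc2nc3cc(Cl)c(OCC4CC4)cc3[nH]2)c2ccccc2c1=O` departs from compound 1 in one place: cyclopropyl in place of methyl on a saturated chain carbon bound to an oxygen on an aromatic ring. Among the compounds with values here, no measured pair shows this change. A modest rise in this assay is expected, resting only on the higher number of compound 2 at 94 L/kg, and it may stay within the scatter. The expected step runs a 1.6-fold higher number from compound 1 to compound 3 (0.20 log units; within the scatter). For compound 3 the estimated value is 16 L/kg, with an expected range of 6 L/kg to 45 L/kg.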

Compound 3, volume of distribution at steady state: 83 L/kg
The estimate for compound 3 lay 5.2-fold (0.71 log units) below the measured number; the measured number lies above the stated range.
By their numbers in this assay, from the lowest: compound 1; then compounds 3 and 2 (each within the scatter of the next).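

In this assay, the position carrying the ether on the shared core proves sensitive: going from ethoxy to cyclopropylmethoxy gives an 8.3-fold higher number from compound 1 to compound 3 (0.92 log units; beyond the scatter) in a single matched pair. Within the data shown here, this is the first size available for this change, since the earlier compounds offered no such pair. No available measurement accounts for the step.

On these data alone, whether the rise follows the cyclopropyl ring or simply the longer substituent remains open. A straight propoxy or butoxy chain at this place would separate the two readings.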